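Amide nitrogen substituent swap from compound 3 to compound 4

The source may report more compounds than this note shows. Statements on the series, on what has been measured and on what is new or still open speak of the compounds shown alone.

Measured so far:
- compound 1, `Cc1noc(C)c1-c1cnc(N)c(Oc2ccc(C(=O)NC3CCCC3)cc2)n1`; in a functional assay on HepG2 cells (Homo sapiens) for inhibition, read by MTT assay, with a stated time of 72 h (a higher number here means a weaker inhibitor, a lower number a stronger inhibitor), compound 1 gives 12800 nM.
- compound 2, `Cc1noc(C)c1-c1cnc(N)c(Oc2ccc(C(=O)Nc3ccccc3Cl)cc2)n1`; in this assay compound 2 reaches only a limit, > 100000 nM.
- compound 3, `Cn1cc(-c2cnc(N)c(Oc3ccc(C(=O)Nc4ccccc4Cl)cc3)n2)cn1`; in this assay compound 3 gives 66900 nM.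

Of the two plain numbers, compound 3 holds the higher one and compound 1 the lower one, a gap beyond the scatter. The series carries two single-site steps. At the amide nitrogen, an at least 7.8-fold higher number from compound 1 to compound 2 (0.89 log units; beyond the scatter); that the value of compound 2 is a limit is noted in the limit of > 100000 nM in this assay, at which 1 of the 3 values shown sits. On the aromatic carbon, an at least 1.4-fold lower number from compound 2 to compound 3 (0.17 log units; that floor lies within the scatter), and the floor of that step lies within the scatter.

Compound 4, `Cn1cc(-c2cnc(N)c(Oc3ccc(C(=O)Nc4ccc(Cl)cn4)cc3)n2)cn1`, is not yet measured. It differs from compound 3 by 5-chloropyridin-2-yl in place of 2-chlorophenyl on an amide-type nitrogen. Among the compounds with values here, no measured step swaps one six-membered aromatic ring for another at that nitrogen; the only step at that position exchanged cyclopentyl for an aryl group. The expectation for this assay is therefore a step of a 1.1-fold lower number from compound 3 to compound 4 (0.05 log units; within the scatter), not beyond the scatter, in either direction. Compound 4 is estimated at 60000 nM, with a range from 20000 nM to 150000 nM, and a real chance that only a limit is reported.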

Compound 4, half-maximal inhibitory concentration: 24200 nM
The estimate for compound 4 lay 2.5-fold (0.39 log units) above the measured number; measured number inside the range.
By their numbers in this assay, from the lowest: compounds 1 and 4 (each within the scatter of the next); then compound 3. At a limit, above all of these: compound 2.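

Within the data shown here, at the amide-type nitrogen, the step in this assay is the first exchange of one six-membered aromatic ring for another, and it gives a 2.8-fold lower number from compound 3 to compound 4 (0.44 log units; beyond the scatter). The position therefore responds to the identity of the aromatic group, which the earlier step from cyclopentyl to 2-chlorophenyl could not show. The change replaces a carbon-only ring with a ring holding one hetero atom and also gives a different chlorine numbering in the group name, so this single step cannot assign the difference to either feature.

On these data alone, it remains open whether pyridin-2-yl without chlorine or 4-chlorophenyl at the same nitrogen would separate the ring nitrogen from the placing of the chlorine. It is also open whether 5-chloropyridin-2-yl gives a comparable step with 3,5-dimethyl-1,2-oxazol-4-yl on the aromatic carbon, since the only aryl amide reference with that group, compound 2, is a limit and not a number: the limit of > 100000 nM in this assay, at which 1 of the 4 values shown sits.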